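From compound 3 to compound 4: a single ring swap

The source may hold more compounds than are shown below. What is called first, only, known or untested is meant among the compounds shown, and "the series" means these compounds.

Three measured compounds share one core and differ only in the ring attached on a saturated chain carbon bound to an amine nitrogen in a ring. Compound 1 `Cc1[nH]ncc1CN1C[C@H](CCCB(O)O)[C@](N)(C(=O)O)C1` gives 400 nM in an assay for inhibition of arginase-1 (Homo sapiens), read by colorimetric assay, with a stated time of 60 min, in the presence of a further agent that is not named here; on this read-out higher numbers stand for weaker inhibition and lower numbers for stronger inhibition. Compound 2 `Cc1nn(C)c(C)c1CN1C[C@H](CCCB(O)O)[C@](N)(C(=O)O)C1` gives 340 nM in this assay, and compound 3 `N[C@@]1(C(=O)O)CN(Cc2ncccc2F)C[C@@H]1CCCB(O)O` gives 670 nM. Compound 3 therefore carries the highest of the three numbers, yet the steps of a 1.7-fold higher number from compound 1 to compound 3 (0.22 log units; within the scatter) and a 2.0-fold higher number from compound 2 to compound 3 (0.29 log units; within the scatter) both lie within the scatter, so no real separation between the three is shown.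

Compound 4 `N[C@@]1(C(=O)O)CN(Cc2ccncc2)C[C@@H]1CCCB(O)O` is not yet measured. It differs from compound 3 in one place: pyridin-4-yl in place of 3-fluoropyridin-2-yl on a saturated chain carbon bound to an amine nitrogen in a ring. Every measured step at this position is a ring swap of the same kind: a 1.2-fold lower number from compound 1 to compound 2 (0.07 log units; within the scatter), alongside the two steps to compound 3 already named. All three are within the scatter, so exchanging one ring for another here has so far left the numbers essentially where they were. Because the step of a 2.0-fold higher number from compound 2 to compound 3 (0.29 log units; within the scatter) is the largest among them and still within the scatter, compound 4 is expected to sit close to compound 3, with a step of a 1.2-fold lower number from compound 3 to compound 4 (0.09 log units; within the scatter) that is not expected to exceed the scatter. The estimate for compound 4 in this assay is 550 nM, within a range from 200 nM to 1500 nM.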

Compound 4, half-maximal inhibitory concentration: 600 nM
Compound 4: the middle estimate sits 1.1-fold (0.04 log units) below what was measured; low and high end bracket the measured number.
By their numbers in this assay, from the lowest: compounds 2, 1, 4 and 3 (each within the scatter of the next).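

Exchanging 3-fluoropyridin-2-yl for pyridin-4-yl removes the fluorine and takes the ring down by one heavy atom, yet in this assay the swap gives a 1.1-fold lower number from compound 3 to compound 4 (0.05 log units; within the scatter). Set against the two pyrazole-based groups, the same ring gives a 1.8-fold higher number from compound 2 to compound 4 (0.25 log units; within the scatter) with 1,3,5-trimethyl-1H-pyrazol-4-yl and a 1.5-fold higher number from compound 1 to compound 4 (0.18 log units; within the scatter) with 5-methyl-1H-pyrazol-4-yl, so a ring without fluorine or methyl groups also stays within the scatter of all three earlier compounds, and none of the four compounds goes against this. No other measurement bears on this result, so what lies behind this flat picture remains unknown.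

The step from compound 3 to compound 4 changes more than the fluorine, as the two group names show, and a plain pyridin-2-yl group would be needed to separate the fluorine from the rest of that change. Going by these compounds, all four groups are aromatic rings, so it remains open whether a saturated ring such as piperidine, or a ring carrying a carboxylic acid, would move the number beyond the scatter.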